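Moving a Fluorine and What Cells Tolerate

The source may hold more compounds than are shown below. What is called first, only, known or untested is meant among the compounds shown, and "the series" means these compounds.

Three compounds have been measured in an ADME assay on MT4 cells (Homo sapiens) for cytotoxicity, read by MTT assay, with a stated time of 4 days; a higher number here means that more compound is tolerated, a lower number that less compound is tolerated:

compound 1 `CC(=O)Nc1ccc2oc(-c3cccc(F)c3)cc(=O)c2c1` gives 240000 nM
compound 2 `CC(=O)Nc1ccc2oc(-c3ccc(F)cc3)cc(=O)c2c1` gives 203000 nM
compound 3 `COc1c(-c2cccc(F)c2)oc2ccc(N)cc2c1=O` gives 113000 nM

Compound 1 and compound 2 share one core and differ in a single group: 4-fluorophenyl in place of 3-fluorophenyl on an aromatic carbon. That change made a step of a 1.2-fold lower number from compound 1 to compound 2 (0.07 log units; within the scatter). Compound 3 is built on another core; the difference between the core of compound 3 and the core of compound 1 is not broken down here. Of the three numbers, compound 3 has the lowest, but its value and that of compound 2 lie within the scatter of each other, while its gap to compound 1 lies beyond it.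

Compound 4 `COc1c(-c2ccc(F)cc2)oc2ccc(N)cc2c1=O` has not yet been measured. It stands to compound 3 as compound 2 stands to compound 1: 4-fluorophenyl in place of 3-fluorophenyl on an aromatic carbon. The surroundings are not identical, though. In compound 3 the place is also ortho to a methoxy group (2 heavy atoms), which the core of compound 1 does not carry, so this is the same kind of change rather than the same one. Because the earlier step was a 1.2-fold lower number from compound 1 to compound 2 (0.07 log units; within the scatter), a similarly small step is expected in this assay, namely a 1.2-fold lower number from compound 3 to compound 4 (0.08 log units; within the scatter). Compound 4 is therefore estimated at 95000 nM, most likely falling between 50000 nM and 200000 nM.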

Compound 4, half-maximal cytotoxic concentration: 141000 nM
Beside the measured number, compound 4's estimate is 1.5-fold (0.17 log units) below it, and the stated range covers the measured number.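

On the core of compound 3, putting 4-fluorophenyl in place of 3-fluorophenyl gives a step of a 1.2-fold higher number from compound 3 to compound 4 (0.10 log units; within the scatter) in this assay. Set beside the same change on the core of compound 1, this step cannot be told apart from the earlier one, so on the evidence of these two pairs the change carries over from one core to the other, even though the place on the core of compound 3 is also ortho to a methoxy group: the same change on two cores in this assay, a 1.2-fold lower number (0.07 log units; within the scatter) from compound 1 to compound 2 and a 1.2-fold higher number (0.10 log units; within the scatter) from compound 3 to compound 4, 1.5-fold (0.17 log units) apart, within the scatter of two such steps

The two steps carry opposite signs, but neither lies beyond the scatter, so the signs should not be read as a real reversal, and the pairs show only that this fluorine shift makes no readable difference to what these cells tolerate on these two cores; they do not show that it would do the same on a third core or in a different assay.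

The compounds shown leave open whether a larger change at the same place would register, such as a chlorine atom or a nitrile in place of the fluorine, or a phenyl ring with no fluorine at all. They also leave open how far the tolerated amount depends on the other parts of the cores, since each pair here varies only the fluorophenyl group.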